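A change of amine on the shared core

A few compounds are considered here, and "the series" means these few. Any claim that something is new, unique, unknown or untested is made for them only; others in the source may bear on it.

Of the compounds shown here, two on the shared core have been measured. Compound 1, `CCN1CCN(c2ccc(Nc3ncc(Cl)c(Nc4ccccc4C)n3)nc2)CC1`, is one of them. In an ADME assay on L02 cells (Homo sapiens) for inhibition, read by CCK-8 assay, with a stated time of 48 h (a higher number here means a weaker inhibitor of growth, a lower number a stronger inhibitor of growth), compound 1 reports only a limit, > 100000 nM. Compound 2, `CN1CCN(c2ccc(Nc3ncc(Cl)c(NCc4ccc(F)cc4)n3)nc2)CC1`, is the other. In this assay, among the compounds with values here, compound 2 gives 39700 nM, the only plain number so far. The other entry is the limit of > 100000 nM in this assay, at which 1 of the 2 values shown sits. Compound 3, `CC(C)c1cccc(Nc2nc(Nc3ccc(N4CCN(C)CC4)cn3)ncc2Cl)c1`, has not yet been measured. It differs from compound 2 by 3-isopropylphenyl in place of 4-fluorobenzyl on a nitrogen on an aromatic ring. Within the data shown here, no step between measured compounds is available to calibrate this change, so any expectation rests on the two values alone and on the change itself. Compound 3 is expected to move by a moderate step toward weaker inhibition of growth, a 1.5-fold higher number from compound 2 to compound 3 (0.18 log units; within the scatter). In this assay compound 3 is estimated at 60000 nM, with a likely range from 20000 nM to 150000 nM.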

Compound 3, concentration for 50% growth inhibition: 12500 nM
Compound 3: the middle estimate sits 4.8-fold (0.68 log units) above what was measured, outside the stated range (below it).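

In this assay, within the data shown here, the group on a nitrogen on an aromatic ring proves able to shift the read-out: 3-isopropylphenyl in place of 4-fluorobenzyl gives a 3.2-fold lower number from compound 2 to compound 3 (0.50 log units; beyond the scatter), the first step on the shared core that can be read. Within this one pair, the change leads to a stronger inhibitor of growth, and by more than the usual scatter. Compound 1 remains a limit and not a number, and it differs from the other two in more than one place, so it adds no step: the limit of > 100000 nM in this assay, at which 1 of the 3 values shown sits.

This single step exchanges benzyl for phenyl and fluorine for isopropyl together, so it cannot say which part carries the shift. Going by these compounds, a 3-isopropylbenzyl or a 4-fluorophenyl on the same nitrogen would separate the two, and how an amine or a carboxylic acid would fare in place of the isopropyl remains open.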